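A few compounds are considered here, and "the series" means these few. Any claim that something is new, unique, unknown or untested is made for them only; others in the source may bear on it.

Measured so far:
compound 1, `COc1ccc2cc(CCC(C)O)ccc2c1`: 32%
compound 2, `CC(=O)CCc1ccc2cc(C)ccc2c1`: 34%

Both results come from a functional assay on the whole organism (strain Wistar) for inhibition, with Rattus norvegicus as the target, with a stated time of 5 days, at a dose of 50 mg/kg by the oral route; a lower number here means less inhibition, a higher number more inhibition at the dose given (going by the name of the read-out). In this assay, within the data shown here, compound 2 gives 34%, and compound 1 gives 32%; the two numbers lie within the scatter of each other, so neither compound is set apart from the other, and no step between them is counted, since the two structures differ in more than one place.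

Compound 3, `Cc1ccc2cc(CCC(C)O)ccc2c1`, has not been measured in this assay. Against compound 2 the change is 1-hydroxyethyl in place of acetyl on a saturated chain carbon, two bonds along the chain from an aromatic carbon. Compound 1 already carries the 1-hydroxyethyl group on the same kind of chain and gives 32%, so the two measured numbers give no sign that this group by itself moves the read-out in either direction.

The step from compound 2 to compound 3 is therefore expected to be a number 1 percentage points lower from compound 2 to compound 3 (within the scatter), that is, no shift beyond the scatter. Compound 3 is estimated at 33%, with a range from 22% to 44%.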

Compound 3, a percentage reported as inhibition, in the whole organism at one dose (the size of the read-out at that dose, not a potency): 35%
The estimate for compound 3 lay 2 percentage points below the measured number; the range from low to high includes it.
By their numbers in this assay, from the lowest: compounds 1, 2 and 3 (each within the scatter of the next).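

In this assay the exchange of acetyl for 1-hydroxyethyl on a saturated chain carbon, two bonds along the chain from an aromatic carbon, can now be read as a change in one place, with a number 1 percentage points higher from compound 2 to compound 3 (within the scatter) and thus no shift beyond the scatter at this dose, even though the entering group carries a hydrogen-bond donor and the leaving group carries none. With 1-hydroxyethyl held constant, methyl in place of methoxy on an aromatic carbon gives a number 3 percentage points higher from compound 1 to compound 3 (within the scatter) and also stays within the scatter, so neither exchange sets one compound apart from another. No measurement on hand offers an explanation for these results.

Still open, from the compounds shown here alone, is whether any other group on this chain would move the read-out beyond the scatter, such as an amine, a carboxylic acid or a longer chain in place of 1-hydroxyethyl. Also open, going by these compounds, is how chlorine or hydroxyl would compare with methyl and methoxy on the aromatic carbon, and since each read-out comes from a single dose, the compounds' relative potency remains unknown.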